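This account rests on a few compounds, and the source may have more. Where it says the series, first, only, none or still open, it means among the compounds named here.

Three compounds built on one shared core have been tested in a functional assay on BJAB cells (Homo sapiens) for antiproliferative activity, with a stated time of 4 days; on this read-out lower numbers stand for an effect already at smaller amounts and higher numbers for an effect only at larger amounts of compound:

Compound 1, `COc1cccc(-c2c(C)nn(-c3nc(-c4ccc(Cl)c(Cl)c4)c(SC(C)C)s3)c2C(=O)O)c1`, gives 14000 nM.
Compound 2, `COc1cncc(-c2c(C)nn(-c3nc(-c4ccc(Cl)c(Cl)c4)c(SC(C)C)s3)c2C(=O)O)c1`, gives 21000 nM.
Compound 3, `Cc1ccc(-c2c(C)nn(-c3nc(-c4ccc(Cl)c(Cl)c4)c(SC(C)C)s3)c2C(=O)O)cc1`, gives 3800 nM.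

Compound 2 has the highest of these three numbers. The step of a 1.5-fold higher number from compound 1 to compound 2 (0.18 log units; within the scatter) lies within the scatter, so compounds 1 and 2 cannot be told apart on this read-out. Compound 3 does stand apart from both: a 3.7-fold lower number from compound 1 to compound 3 (0.57 log units; beyond the scatter) and a 5.5-fold lower number from compound 2 to compound 3 (0.74 log units; beyond the scatter).

Compound 4, `Cc1nn(-c2nc(-c3ccc(Cl)c(Cl)c3)c(SC(C)C)s2)c(C(=O)O)c1-c1ccccc1Cl`, has not yet been measured. It differs from compound 2 in one place: 2-chlorophenyl in place of 5-methoxypyridin-3-yl on an aromatic carbon. The measured steps that bear on this change are the ones in which the group on that same aromatic carbon was exchanged. Two of them were modest and ran toward lower numbers, a 3.7-fold lower number from compound 1 to compound 3 (0.57 log units; beyond the scatter) and a 5.5-fold lower number from compound 2 to compound 3 (0.74 log units; beyond the scatter), both ending at compound 3, which like compound 4 carries a six-membered ring of carbon only with no hydrogen-bond acceptors. The third, a 1.5-fold higher number from compound 1 to compound 2 (0.18 log units; within the scatter), was within the scatter. A lower number for compound 4 is therefore expected, of modest size, because the step of a 5.5-fold lower number from compound 2 to compound 3 (0.74 log units; beyond the scatter) went that way for a related exchange. The estimated step of a 3.0-fold lower number from compound 2 to compound 4 (0.48 log units; beyond the scatter) is expected to run downward. Compound 4 is estimated at 7000 nM, within a range from 2500 nM to 20000 nM.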

Compound 4, half-maximal effective concentration: 13100 nM
Beside the measured number, compound 4's estimate is 1.9-fold (0.27 log units) below it; measured number inside the range.
By their numbers in this assay, from the lowest: compound 3; then compounds 4, 1 and 2 (each within the scatter of the next).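

In this assay, placing 2-chlorophenyl on this aromatic carbon leaves the number within the scatter of both compounds that carry a methoxy group (a 1.6-fold lower number from compound 2 to compound 4 (0.20 log units; within the scatter); a 1.1-fold lower number from compound 1 to compound 4 (0.03 log units; within the scatter)), so compounds 1, 2 and 4 cannot be told apart. A six-membered ring of carbon only, with no hydrogen-bond acceptors, therefore does not by itself bring the number down at this position, and compound 3 still stands apart from compound 4 (a 3.4-fold higher number from compound 3 to compound 4 (0.54 log units; beyond the scatter)). Among the four groups tested here, only 4-methylphenyl gives a number separate from the rest, so the low number of compound 3 goes with that particular substituted ring, not with carbon-only rings as a class, and compound 4 is the one that goes against such a class pattern.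

Nothing available here explains why these two carbon-only rings differ. Still open, as far as these compounds go, is whether the lower number follows the methyl group itself or the ring carbon that carries it, and how a plain phenyl ring, or a ring bearing an amine in place of the methyl group, would read in this assay.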